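The source may hold more compounds than are shown below. What is called first, only, known or untested is meant among the compounds shown, and "the series" means these compounds.

In a functional assay on HCT-116 cells (Homo sapiens) for antiproliferative activity, read by MTT assay (on this read-out higher numbers stand for weaker inhibition and lower numbers for stronger inhibition), three compounds of one family have been measured so far. Compound 1, `CCOC(=O)/C=N/c1cnc(Nc2ccc(S(N)(=O)=O)cc2)nc1NC1CCCC1`, gives 9640 nM. Compound 2, `NS(=O)(=O)c1ccc(Nc2ncc(/N=C/c3ccccc3)c(NC3CCCC3)n2)cc1`, gives 26100 nM. Compound 3, `CCOC(=O)/C=N/c1cnc(Nc2ccc(N3CCN(C)CC3)cc2)nc1NC(C)C`, gives 13600 nM. The first two compounds share one core and differ in a single place: phenyl in place of ethoxycarbonyl on a carbon with a double bond to nitrogen. That change made a 2.7-fold higher number from compound 1 to compound 2 (0.43 log units; beyond the scatter), a modest weakening of growth inhibition. Compound 3 carries a different core, and how its core differs from that of compound 1 is not broken down here. Its number lies within the usual scatter of both compound 1 and compound 2, so these three values alone do not set compound 3 apart from either.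

Compound 4, `CC(C)Nc1nc(Nc2ccc(N3CCN(C)CC3)cc2)ncc1/N=C/c1ccccc1`, has not yet been measured. It stands to compound 3 as compound 2 stands to compound 1: phenyl in place of ethoxycarbonyl on a carbon with a double bond to nitrogen. The place of the change is described in the same words in both pairs, so this is the same change carried onto a second core. Because the same change once gave a 2.7-fold higher number from compound 1 to compound 2 (0.43 log units; beyond the scatter), a step of about a 2.6-fold higher number from compound 3 to compound 4 (0.41 log units; beyond the scatter) is expected from the second pair as well. Compound 4 is therefore expected to give roughly 35000 nM. Within the data shown here, the range for compound 4 is estimated to run from 14000 nM to 85000 nM, kept wide since only one earlier example of this change exists and it sits on a different core.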

Compound 4, half-maximal inhibitory concentration: > 100000 nM
Compound 4: only a limit was reported (the forecaster's own chance of this, stated with the estimate: 15%); middle value at least 2.8-fold (0.45 log units) from the limit.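

In this assay, putting phenyl in place of ethoxycarbonyl on a carbon with a double bond to nitrogen weakened growth inhibition on the second core as it did on the first, giving an at least 7.3-fold higher number from compound 3 to compound 4 (0.86 log units; beyond the scatter). Compound 4 gives > 100000 nM, which is a limit of the assay and not a number. The change therefore kept its direction on both cores but did not keep its size, so the step measured on one core was a poor guide to the size of the step on the other; these two pairs do not show how large the second step truly is, nor why the two steps differ: the same change on two cores in this assay, a 2.7-fold higher number (0.43 log units; beyond the scatter) from compound 1 to compound 2 and an at least 7.3-fold higher number (0.86 log units; beyond the scatter) from compound 3 to compound 4, at least 2.7-fold (0.43 log units) apart, beyond the scatter of two such steps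

Among these compounds, with only two cores, it remains open which part of the core goes with the larger step, and whether a third core would give a step closer to the first or to the second. As far as these compounds go, it is also open how other groups on that same carbon would behave on both cores, such as a carboxylic acid, an amide or a short alkyl chain, and whether any of them would keep growth inhibition at the level seen with ethoxycarbonyl.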